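This account rests on a few compounds, and the source may have more. Where it says the series, first, only, none or still open, it means among the compounds named here.

Measured in an ADME assay on Akata cells (Homo sapiens) for cytotoxicity, with a stated time of 7 days; a higher number here means that more compound is tolerated, a lower number that less compound is tolerated:
- compound 1 `CC(C)CSc1nc(N)nc2c1ncn2/C=C1/CC1(CO)CO`: > 20000 nM, a limit
- compound 2 `Nc1nc(NC2CCCCC2)c2ncn(/C=C3/CC3(CO)CO)c2n1`: > 24000 nM, a limit

Compound 2 has no exact number in this assay: its > 24000 nM is a limit. Going by the values given here, the only other value, for compound 1, is also a limit, so compound 2 cannot be ranked.

The next compound is compound 3 `CCCCCCSc1nc(N)nc2c1ncn2/C=C1/CC1(CO)CO`, with hexylsulfanyl in place of cyclohexylamino on an aromatic carbon. Among the compounds with values here, the one measured step bearing on this change is a step that the two limits leave unreadable from compound 1 to compound 2, which joins a sulfanyl compound to an amino compound at the same place. Its size cannot be read, so it gives no magnitude to carry over. Within the data shown here, the closest guide is compound 1, the only measured sulfanyl compound, whose > 20000 nM is a limit. Going by these compounds, no step beyond the scatter is therefore expected, although a hexylsulfanyl chain is untested here and the uncertainty is wide. The expected step is an at least 1.2-fold lower number from compound 2 to compound 3 (0.07 log units; that floor lies within the scatter). The estimate for compound 3 is 20000 nM, with an expected range of 6000 nM to 40000 nM.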

Compound 3, half-maximal cytotoxic concentration: > 20000 nM
Compound 3: only a limit was reported; the forecaster's own chance of this, stated with the estimate: 55%; the middle value sits exactly at the limit.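

In this assay compound 3 gives > 20000 nM, a limit. Going by these compounds alone, compound 1 and compound 2 also carry limits, so no step among compound 1, compound 2 and compound 3 can be read. The compounds shown leave open whether hexylsulfanyl, isobutylsulfanyl and cyclohexylamino differ at all in this assay.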